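Compound 3 to compound 4: naphthalen-2-yl on the carbonyl

The source may hold more compounds than are shown below. What is called first, only, known or untested is meant among the compounds shown, and "the series" means these compounds.

In a functional assay on HCT-116 cells (Homo sapiens) for inhibition, read by MTT assay, with a stated time of 48 h (a lower number here means a stronger inhibitor, a higher number a weaker inhibitor), compound 1 (`CCSc1nnc(-c2cc(OC)c(OC)c(OC)c2)n1-c1ccc(N(C)C)cc1`) gives > 60000 nM as a limit of the assay. Compound 3 (`COc1ccc(C(=O)CSc2nnc(-c3cc(OC)c(OC)c(OC)c3)n2-c2ccc(N(C)C)cc2)cc1O`) gives > 100000 nM as a limit too, so it has no exact number. Within the data shown here, compound 2 (`COc1ccc(CSc2nnc(-c3cc(OC)c(OC)c(OC)c3)n2-c2ccc(N(C)C)cc2)cc1`) reads 1150 nM as the only exact value. Compound 4 (`COc1cc(-c2nnc(SCC(=O)c3ccc4ccccc4c3)n2-c2ccc(N(C)C)cc2)cc(OC)c1OC`) has naphthalen-2-yl in place of 3-hydroxy-4-methoxyphenyl on a carbonyl carbon. Among the measured compounds shown here, no measured step changes that group alone. The nearest steps on the chain are the large at least 52-fold lower number from compound 1 to compound 2 (1.71 log units; beyond the scatter) and the large at least 86-fold higher number from compound 2 to compound 3 (1.93 log units; beyond the scatter) and they point opposite ways. A gain is expected only cautiously, since compound 3 keeps an aromatic group and stays at its limit. The expected shift toward a lower number is an at least 8.3-fold lower number from compound 3 to compound 4 (0.92 log units; beyond the scatter) in this assay and remains uncertain. For compound 4 the estimate is 12000 nM with an expected range of 2000 nM to 70000 nM in this assay here.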

Compound 4, half-maximal inhibitory concentration: 54500 nM
For compound 4 the middle estimate is 4.5-fold (0.66 log units) below the measured one, within the range that was stated.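

In this assay, naphthalen-2-yl on the carbonyl gives a measurable reading but does not recover the level of the 4-methoxyphenyl group, with a 47-fold higher number from compound 2 to compound 4 (1.68 log units; beyond the scatter). The other two steps, an at least 1.8-fold lower number from compound 3 to compound 4 (0.26 log units; that floor lies within the scatter) and an at least 1.1-fold lower number from compound 1 to compound 4 (0.04 log units; that floor lies within the scatter), give only floors, so no gain is established. The size of the aryl exchange on the carbonyl stays unread because compound 3 sits at a limit: the limit of > 100000 nM in this assay, at which 1 of the 4 values shown sits.

Open, as far as these compounds go, is whether the loss follows the carbonyl or the aryl group, which a naphthalen-2-yl group directly on the saturated chain carbon bound to a sulfur would separate. Also open, from the compounds shown here alone, is how an amide or a carboxylic acid at that carbon would read.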